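A Pyridine Ring Replaces the Formylphenyl Group

A few compounds are considered here, and "the series" means these few. Any claim that something is new, unique, unknown or untested is made for them only; others in the source may bear on it.

Three close relatives of one shared core have been tested in an ADME assay on HepG2 cells (Homo sapiens) for cytotoxicity, read by MTT assay, with a stated time of 72 h; a lower number here means that less compound is tolerated, a higher number that more compound is tolerated. Compound 1 `N#Cc1ccc(-c2cc(Cl)cn3c([N+](=O)[O-])c(CS(=O)(=O)c4ccccc4)nc23)cc1` gives a value that is a limit of the assay, > 3900 nM. Compound 3 `O=[N+]([O-])c1c(CS(=O)(=O)c2ccccc2)nc2c(-c3ccc(F)cc3)cc(Cl)cn12` likewise gives a limit, > 15600 nM. Compound 2 `O=Cc1ccc(-c2cc(Cl)cn3c([N+](=O)[O-])c(CS(=O)(=O)c4ccccc4)nc23)cc1` stands at a limit as well, > 31200 nM, so only a limit is known for it. The two further values shown are also limits. With all three at limits, the steps between them cannot be read: a step that the two limits leave unreadable from compound 1 to compound 2, a step that the two limits leave unreadable from compound 1 to compound 3 and a step that the two limits leave unreadable from compound 2 to compound 3. Compound 4 `O=[N+]([O-])c1c(CS(=O)(=O)c2ccccc2)nc2c(-c3cccnc3)cc(Cl)cn12` differs from compound 2 by pyridin-3-yl in place of 4-formylphenyl on an aromatic carbon. For the measured compounds named here, no measured step carries a readable size for this change, so no shift beyond the usual scatter is expected in this assay. Compound 4 is estimated at 30000 nM, with a range from 8000 nM to 100000 nM. This expectation means a step of an at least 1.0-fold lower number from compound 2 to compound 4 (0.01 log units; that floor lies within the scatter).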

Compound 4, half-maximal cytotoxic concentration: > 31300 nM
Compound 4: no number, only a limit (the forecaster's own chance of this, stated with the estimate: 75%); middle value at least 1.0-fold (0.01 log units) away from the limit.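

Compound 4 gives only a limit, > 31300 nM, so its steps to compound 1, compound 2 and compound 3, which also stand at limits, cannot be read. Going by these compounds, the actual cytotoxic concentrations of all four compounds remain open, as does whether any of these ring changes shifts them.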